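Sulfamoyl carbamates and ureas on a diisopropylphenyl core

A few compounds are considered here, and "the series" means these few. Any claim that something is new, unique, unknown or untested is made for them only; others in the source may bear on it.

Measured compounds:
compound 1, `CCCCN(C)S(=O)(=O)NC(=O)Nc1c(C(C)C)cccc1C(C)C`, 2300 nM
compound 2, `CC(C)c1cccc(C(C)C)c1OC(=O)NS(=O)(=O)N(C(C)C)C1CCCCC1`, 5100 nM
compound 3, `CC(C)c1cc(C(C)(C)C)cc(C(C)C)c1OC(=O)NS(=O)(=O)Oc1c(C(C)C)cccc1C(C)C`, 8800 nM

In an assay on liver for inhibition of sterol O-acyltransferase 1 (Rattus norvegicus), using microsomes (on this read-out lower numbers stand for stronger inhibition and higher numbers for weaker inhibition), compound 1 gives 2300 nM, compound 2 gives 5100 nM and compound 3 gives 8800 nM. Compound 3 and compound 2 lie within the scatter of each other; the gap from compound 3 to compound 1 is beyond the scatter, with compound 1 giving the lower number. No two of the three measured compounds differ in one place only, so no single step is shown from which to read a change.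

Compound 4, `CC(C)c1cc(O)cc(C(C)C)c1OC(=O)NS(=O)(=O)Oc1c(C(C)C)cccc1C(C)C`, is not yet measured in this assay. It differs from compound 3 by hydroxy in place of tert-butyl on an aromatic carbon. Among the compounds with values here, nothing among the measured compounds shows a hydroxy group anywhere, so the size of this step has no precedent here. In this assay the expectation for compound 4 is a small step, if any, toward a higher number, not clearly beyond the scatter. Compound 4 is estimated at 12000 nM, with a range from 4000 nM to 40000 nM. This estimate means an expected step of a 1.4-fold higher number from compound 3 to compound 4 (0.13 log units; within the scatter).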

Compound 4, half-maximal inhibitory concentration: > 50000 nM
Compound 4: no number, only a limit (the forecaster's own chance of this, stated with the estimate: 15%); middle value at least 4.1-fold (0.61 log units) away from the limit.
By their numbers in this assay, from the lowest: compound 1; then compounds 2 and 3 (each within the scatter of the next). At a limit, above all of these: compound 4.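

In this assay compound 4 gives no number, only a limit: the limit of > 50000 nM in this assay, at which 1 of the 4 values shown sits. Hydroxy in place of tert-butyl, on the aromatic carbon meta to two isopropyl groups and para to a large group, is the first change in the series made in one place only, and it gives an at least 5.6-fold higher number from compound 3 to compound 4 (0.75 log units; beyond the scatter), so this position is not indifferent to what it carries. The step is a bound, so its full size cannot be read from it.

From the compounds shown here alone, whether the shift follows from the entering hydroxy or from the departing tert-butyl stays open; a methoxy group, a fluorine or a plain hydrogen at this position would separate the two. Also open, going by these compounds, is whether the same exchange would act alike on the urea of compound 1.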